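Hydroxy to Amino on a Shared Amide Side Chain

A few compounds are considered here, and "the series" means these few. Any claim that something is new, unique, unknown or untested is made for them only; others in the source may bear on it.

Compound 1 `COc1ccc(C(=O)c2ccc(OC)c3c2C=CC(C)(C)O3)c(NC(=O)CO)c1` gives 310 nM in a functional assay on HeLa cells (Homo sapiens) for antiproliferative activity, read by MTT assay, with a stated time of 48 h; a higher number here means a weaker inhibitor, a lower number a stronger inhibitor.
Compound 2 `COc1ccc(C(=O)c2ccc3c(c2)C=CC(C)(C)O3)c(NC(=O)CO)c1` gives 240 nM.
Compound 3 `COc1ccc(C(=O)c2ccc(OC)c3c2C=CC(C)(C)O3)c(NC(=O)CN)c1` gives 100 nM.

Compound 1 and compound 2 carry the same side chain on different cores; how the two cores differ is not broken down here, and their two values lie within the usual scatter of each other. Compound 3 differs from compound 1 by amino in place of hydroxy on a saturated chain carbon bound to a carbonyl carbon, and that single change gave a 3.1-fold lower number from compound 1 to compound 3 (0.49 log units; beyond the scatter).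

Compound 4 `COc1ccc(C(=O)c2ccc3c(c2)C=CC(C)(C)O3)c(NC(=O)CN)c1` is not yet measured. It differs from compound 2 by amino in place of hydroxy on a saturated chain carbon bound to a carbonyl carbon, the same change at the same place, now on the core of compound 2. Because a 3.1-fold lower number from compound 1 to compound 3 (0.49 log units; beyond the scatter) was beyond the scatter, a step of comparable size is expected, a 3.0-fold lower number from compound 2 to compound 4 (0.48 log units; beyond the scatter), though one earlier example is a thin basis. Compound 4 is therefore estimated at 80 nM, most likely between 40 nM and 200 nM.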

Compound 4, half-maximal inhibitory concentration: 580 nM
Compound 4: the middle estimate sits 7.3-fold (0.86 log units) below what was measured; measured number outside the range, above it.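

On the core of compound 2, amino in place of hydroxy gave a 2.4-fold higher number from compound 2 to compound 4 (0.38 log units; beyond the scatter), so the gain seen on the core of compound 1 did not carry over. Set side by side in this assay, the two steps run in opposite directions and do not agree: the same change on two cores in this assay, a 3.1-fold lower number (0.49 log units; beyond the scatter) from compound 1 to compound 3 and a 2.4-fold higher number (0.38 log units; beyond the scatter) from compound 2 to compound 4, 7.5-fold (0.87 log units) apart, beyond the scatter of two such steps This shows that, for these two pairs, the outcome of the change depends on the core, but it does not show which feature of the core is responsible or what the change would do on a third core.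

Still open, going by these compounds, is how a dimethylamino group or a longer chain ending in an amine would behave on each of the two cores.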